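Swapping cyclopentyl for oxetan-3-yl on compound 1

A few compounds are considered here, and "the series" means these few. Any claim that something is new, unique, unknown or untested is made for them only; others in the source may bear on it.

Measured in a functional assay on CAL-51 cells (Homo sapiens) for antiproliferative activity, read by luminescence and CellTiter-Glo, with a stated time of 3 days; a higher number here means a weaker inhibitor, a lower number a stronger inhibitor:
- compound 1 (`COc1cc(C(=O)N(C)C)ccc1Nc1nc(OC2CCCC2)c2cc[nH]c2n1`): 497 nM
- compound 2 (`CN(C)C(=O)c1ccc(Nc2nc(O[C@H]3CC[C@@](C)(O)CC3)c3cc[nH]c3n2)c(OCC(F)(F)F)c1`): 15 nM

Of these two measurements, compound 1 has the higher number and so is the weaker inhibitor. Its gap to compound 2 lies beyond the usual scatter of repeated measurements. The next molecule to be tested is compound 3 (`COc1cc(C(=O)N(C)C)ccc1Nc1nc(OC2COC2)c2cc[nH]c2n1`), which keeps the core of compound 1 and changes one group: oxetan-3-yl in place of cyclopentyl on an oxygen on an aromatic ring. In words, oxetan-3-yl takes the place of cyclopentyl on an oxygen on an aromatic ring.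

Going by the values given here, no measured pair here differs in only one place, so no direct precedent exists for this swap. The expectation therefore starts from compound 1 at 497 nM and carries wide uncertainty. A moderately weaker inhibitor is expected, meaning a higher number, and the estimated change is a 3.0-fold higher number from compound 1 to compound 3 (0.48 log units; beyond the scatter) in this assay. Compound 3 is estimated at 1500 nM with an expected range of 400 nM to 6000 nM.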

Compound 3, half-maximal inhibitory concentration: 1960 nM
The estimate for compound 3 lay 1.3-fold (0.12 log units) below the measured number; the measured number falls inside the stated range.
By their numbers in this assay, from the lowest: compound 2; then compound 1; then compound 3.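

In this assay, going by these compounds alone, this is the first view of the group on the oxygen on an aromatic ring changing while the rest of compound 1 stays fixed: oxetan-3-yl in place of cyclopentyl gives a 3.9-fold higher number from compound 1 to compound 3 (0.60 log units; beyond the scatter) in a modest step that lies beyond the usual scatter. The position therefore responds to what sits on it, yet the change does not remove activity, as compound 3 still gives a measurable 1960 nM in this assay. Ring size and the ring oxygen, a hydrogen-bond acceptor that cyclopentyl lacks, change together in this single swap, and nothing available separates their contributions or explains the step.

Cyclobutyl, with a four-membered ring of carbon only, and tetrahydrofuran-3-yl, with a five-membered ring holding one oxygen, would each alter just one of those two features and show which one tracks the change in number. As far as these compounds go, it also remains open whether an amine-bearing ring such as azetidin-3-yl would behave like oxetan-3-yl, and whether the same swap would give a similar step on a different group of the shared core.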